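The source may hold more compounds than are shown below. What is called first, only, known or untested is meant among the compounds shown, and "the series" means these compounds.

Within the data shown here, in a functional assay on MOLT-3 cells (Homo sapiens) (a higher number here means a weaker inhibitor, a lower number a stronger inhibitor), compound 1 `CCSC[C@H](NC(C)=O)C(=O)CCl` gives 99900 nM, the highest of the three numbers measured so far. Compound 2 `CCCCCCSC[C@H](NC(C)=O)C(=O)CCl` gives 700 nM, and compound 3 `CCCCCCCSC[C@H](NC(C)=O)C(=O)CCl` gives 2500 nM. Compound 4 `CCCCCCCCSC[C@H](NC(C)=O)C(=O)CCl` has not yet been measured, and it differs from compound 1 by hexyl in place of hydrogen on a saturated chain carbon, two bonds along the chain from a sulfur. Two steps of the same kind bear on this change: butyl gives a 140-fold lower number from compound 1 to compound 2 (2.15 log units; beyond the scatter), and pentyl gives a 40-fold lower number from compound 1 to compound 3 (1.60 log units; beyond the scatter), both large. However, lengthening the chain by one methyl gives a 3.6-fold higher number from compound 2 to compound 3 (0.55 log units; beyond the scatter), a modest rise. A large drop in this assay is therefore still expected, though probably smaller than either of those two. The expected step is a 20-fold lower number from compound 1 to compound 4 (1.30 log units; beyond the scatter). Compound 4 is estimated at 5000 nM, with an expected range of 1500 nM to 20000 nM.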

Compound 4, half-maximal inhibitory concentration: 4100 nM
For compound 4 the middle estimate is 1.2-fold (0.09 log units) above the measured one; the measured number falls inside the stated range.
By their numbers in this assay, from the lowest: compound 2; then compounds 3 and 4 (each within the scatter of the next); then compound 1.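

In this assay hexyl still gives a 24-fold lower number from compound 1 to compound 4 (1.39 log units; beyond the scatter) and so the large drop holds at this chain length. One further methyl gives a 1.6-fold higher number from compound 3 to compound 4 (0.21 log units; within the scatter) while ethyl added to the chain of compound 2 gives a 5.9-fold higher number from compound 2 to compound 4 (0.77 log units; beyond the scatter) and so compound 2 keeps the lowest number, with only a modest loss at the longest chain shown. Nothing measured here explains these shifts. As far as these compounds go, whether a still longer chain would continue this slow rise remains open. So does the effect of an amine or a carboxylic acid at the end of the chain.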